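This account rests on a few compounds, and the source may have more. Where it says the series, first, only, none or still open, it means among the compounds named here.

Measured so far in an assay on isolated protein for inhibition of vitamin D3 receptor (Homo sapiens), read by fluorescence polarization; a lower number here means a stronger inhibitor, a higher number a weaker inhibitor:
- Compound 1 `CS(=O)(=O)c1ccc(C(=O)NCC(=O)N(Cc2ccccc2)Cc2ccccc2)cc1[N+](=O)[O-]`: compound 1 gives > 60000 nM, a limit of the assay.
- Compound 2 `CN(Cc1cccc(F)c1)C(=O)CNC(=O)c1ccc(S(C)(=O)=O)c([N+](=O)[O-])c1`: compound 2 gives > 60000 nM, a limit of the assay.
- Compound 3 `CN1CCN(C(=O)CNC(=O)c2ccc(S(C)(=O)=O)c([N+](=O)[O-])c2)CC1`: compound 3 gives > 60000 nM, a limit of the assay.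

Compound 3 stands nowhere in particular on these numbers: its value in this assay is a limit only, and no number separates it from the other two. (the limit of > 60000 nM in this assay, at which 3 of the 3 values shown sit), so none of the three can be ranked against another.

Compound 4 `CN(Cc1ccccc1)C(=O)CNC(=O)c1ccc(S(C)(=O)=O)c([N+](=O)[O-])c1` is the next member. Against compound 3 the change is benzyl(methyl)amino in place of 4-methylpiperazin-1-yl on a carbonyl carbon. Among the compounds with values here, no measured step between any two compounds exists here, so nothing tells how a change at this carbonyl carbon moves the read-out. What the data do show is that amides of the same core carrying benzyl groups or the methylpiperazine all stay at the limit. For compound 4 the step is expected to be none beyond the scatter, a step that the limit leaves unreadable from compound 3 to compound 4. The estimate for compound 4 is therefore 80000 nM, expected within 40000 nM to 200000 nM, most likely again reported only as a limit.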

Compound 4, half-maximal inhibitory concentration: > 60000 nM
Compound 4 gave a limit, no number; the forecaster's own chance of this, stated with the estimate: 85%; the middle value is on the limit's open side.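

No step can be read from compound 1, compound 2 or compound 3 to compound 4 in this assay, and these compounds cannot be ranked, because all four give only a limit: the limit of > 60000 nM in this assay, at which 4 of the 4 values shown sit. The compounds shown leave open whether any change on the shared core gives a measurable value.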